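Working notes: from compound 3 to compound 4

The source may report more compounds than this note shows. Statements on the series, on what has been measured and on what is new or still open speak of the compounds shown alone.

Values in a functional assay on HT-29 cells (Homo sapiens) for inhibition, read by MTT assay, with a stated time of 48 h (a higher number here means a weaker inhibitor, a lower number a stronger inhibitor), each a limit:
- compound 1 `COc1ccc(-n2c(SCc3ccc(C)cc3)nnc2-c2cc(OC)c(OC)c(OC)c2)cc1` gives > 60000 nM
- compound 2 `COc1ccc(C(=O)CSc2nnc(-c3cc(OC)c(OC)c(OC)c3)n2-c2ccc(OC)cc2)cc1` gives > 60000 nM
- compound 3 `CCSc1nnc(-c2cc(OC)c(OC)c(OC)c2)n1-c1ccc(N(C)C)cc1` gives > 60000 nM

Compound 3 gives > 60000 nM in this assay and this is a limit, not a number. It stands level with the other two compounds, and the whole evidence so far is the limit of > 60000 nM in this assay, at which 3 of the 3 values shown sit, with no measured number anywhere in the series.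

The step to compound 4 `COc1ccc(C(=O)CSc2nnc(-c3cc(OC)c(OC)c(OC)c3)n2-c2ccc(N(C)C)cc2)cc1O` is (3-hydroxy-4-methoxyphenyl)carbonyl in place of methyl on a saturated chain carbon bound to a sulfur and reads in words as (3-hydroxy-4-methoxyphenyl)carbonyl in place of methyl on a saturated chain carbon bound to a sulfur.

Among the measured compounds shown here, the one measured step bearing on this change is a step that the two limits leave unreadable from compound 1 to compound 2 and it also brings an arylcarbonyl group onto that chain carbon. No size can be carried over from it. Any number for compound 4 would have to lie on the stronger side of the limit of compound 3, so the direction is the only thing open to expectation, and a result at the same limit remains quite possible.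

The expected step is an at least 20-fold lower number from compound 3 to compound 4 (1.30 log units; beyond the scatter) toward stronger inhibition, a loose estimate with no readable step behind it.

Compound 4 is estimated at 3000 nM in this assay with an expected range from 50 nM to 60000 nM as its ends.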

Compound 4, half-maximal inhibitory concentration: > 60000 nM
Compound 4: only a limit was reported; the forecaster's own chance of this, stated with the estimate: 35%; middle value at least 20-fold (1.30 log units) from the limit.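

In this assay compound 4 gives > 60000 nM, which is a limit and not a number. No step can be read from compound 3 to compound 4, because both stand only as limits: the limit of > 60000 nM in this assay, at which 4 of the 4 values shown sit.

The compounds shown leave open how strong any of them is in this assay, and which change to the shared core would give a measured number.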